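Phenyl in Place of Methyl: Expected Cytotoxicity of Compound 3

This account rests on a few compounds, and the source may have more. Where it says the series, first, only, none or still open, it means among the compounds named here.

Compound 2 `CC[C@@H](CCn1cncn1)c1ccc(Cl)cc1` was tested in an ADME assay on HEp-2 cells (Homo sapiens) for cytotoxicity, read by MTT assay, with a stated time of 3 days (on this read-out higher numbers stand for lower toxicity in this test and lower numbers for higher toxicity in this test), where compound 2 gives 55.1 ug/mL. Within the data shown here, that is the highest of the two numbers so far, yet its only neighbour, compound 1 `CC[C@H](CCn1cncn1)c1ccc(Cl)cc1`, lies within the scatter: compound 1 gives 50.6 ug/mL, and the step of a 1.1-fold higher number from compound 1 to compound 2 (0.04 log units; within the scatter) is too small to read as a real difference. Those two compounds differ only in the configuration as drawn (the fact that compounds 1 and 2 differ only in the configuration as drawn).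

Compound 3 `Clc1ccc([C@H](CCn2cncn2)Cc2ccccc2)cc1` has not yet been measured. It differs from compound 2 by phenyl in place of methyl on a saturated chain carbon, two bonds along the chain from an aromatic carbon. Among the measured compounds shown here, no measured step touches this kind of change; the single known step concerns configuration alone, was within the scatter, and says nothing about replacing methyl with phenyl. The expectation therefore rests on the size of the structural change itself: compound 3 is expected to show a 1.8-fold lower number from compound 2 to compound 3 (0.26 log units; within the scatter). Compound 3 is estimated at 30 ug/mL, with a range from 10 ug/mL to 80 ug/mL.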

Compound 3, half-maximal cytotoxic concentration: 25.7 ug/mL
Estimate against measurement, compound 3: 1.2-fold (0.07 log units) above; measured number inside the range.
By their numbers in this assay, from the lowest: compounds 3, 1 and 2 (each within the scatter of the next, the first and the last beyond it).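

Putting phenyl in place of methyl on this saturated chain carbon gives a 2.1-fold lower number from compound 2 to compound 3 (0.33 log units; beyond the scatter) in this assay. Among these compounds, this is the first step to pass the usual scatter, and it points towards higher toxicity in this test, though only modestly, whereas the earlier step, a change of configuration alone, could not be read as a real difference. So the group at this place can move the number, but nothing shown here gives a reason for this step.

On these data alone, it remains open whether a longer chain with no ring would move the number as phenyl does, which would help separate the effect of adding carbon atoms from that of adding a ring. As far as these compounds go, an amine or a carboxylic acid at the same place, and the opposite configuration of compound 3, also remain open.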